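Amide aryl exchanges on a shared core: compound 4

The source may hold more compounds than are shown below. What is called first, only, known or untested is meant among the compounds shown, and "the series" means these compounds.

Three compounds share one core and differ only in the aryl on the amide nitrogen. Compound 1 `O=C(CSc1nc(Nc2ccccc2)c2ccccc2n1)Nc1ccccc1Br` gives 10300 nM in a functional assay on NCI-H1975 cells (Homo sapiens) for inhibition, read by MTT assay, with a stated time of 72 h; on this read-out higher numbers stand for weaker inhibition and lower numbers for stronger inhibition; compound 2 `O=C(CSc1nc(Nc2ccccc2)c2ccccc2n1)Nc1ccc(F)cc1` gives 16500 nM; compound 3 `CCc1ccc(NC(=O)CSc2nc(Nc3ccccc3)c3ccccc3n2)cc1` gives 9910 nM. Compound 3 sits alongside the other two: a 1.0-fold lower number from compound 1 to compound 3 (0.02 log units; within the scatter), a 1.7-fold lower number from compound 2 to compound 3 (0.22 log units; within the scatter), and likewise a 1.6-fold higher number from compound 1 to compound 2 (0.20 log units; within the scatter). Compound 4 `O=C(CSc1nc(Nc2ccccc2)c2ccccc2n1)Nc1ccc(F)c(Cl)c1` carries 3-chloro-4-fluorophenyl in place of 4-ethylphenyl on an amide-type nitrogen. All three measured steps bear on this change, since each exchanges the aryl on the amide nitrogen, and none of them left the scatter. The step to compound 4 is therefore expected to be of the same kind, a 1.1-fold higher number from compound 3 to compound 4 (0.05 log units; within the scatter), with no direction beyond the scatter. The expected value for compound 4 in this assay is 11000 nM, within 5000 nM to 25000 nM.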

Compound 4, half-maximal inhibitory concentration: 9390 nM
Beside the measured number, compound 4's estimate is 1.2-fold (0.07 log units) above it; the measured number falls inside the stated range.
By their numbers in this assay, from the lowest: compounds 4, 3, 1 and 2 (each within the scatter of the next).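

The 3-chloro-4-fluorophenyl group keeps this amide position flat in this assay: a 1.1-fold lower number from compound 3 to compound 4 (0.02 log units; within the scatter), and a 1.1-fold lower number from compound 1 to compound 4 (0.04 log units; within the scatter). The new information is the chloro in place of hydrogen on the 4-fluorophenyl, a change on an already substituted aryl, which also stays inside the scatter: a 1.8-fold lower number from compound 2 to compound 4 (0.24 log units; within the scatter). No measurement available here accounts for this flatness.

As far as these compounds go, whether an aryl carrying a carboxylic acid or an amine would leave the scatter remains open. So does the effect of a longer chain in place of the aryl on the amide nitrogen.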